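Hydroxyethyl for oxanyl on the ring nitrogen: permeability outlook

This account rests on a few compounds, and the source may have more. Where it says the series, first, only, none or still open, it means among the compounds named here.

Measured compounds:
- compound 1 `COc1ccc(Cn2c(-c3ccccc3)c(-c3ccccc3)c3c(=N)n(C4CCOCC4)cnc32)cc1` — "nd" (no result reported)
- compound 2 `N=c1c2c(-c3ccccc3)c(-c3ccccc3)n(CC3CC3)c2ncn1C1CCOCC1` — > 1000 10^-6 cm/s

Compound 1 `COc1ccc(Cn2c(-c3ccccc3)c(-c3ccccc3)c3c(=N)n(C4CCOCC4)cnc32)cc1` has no single number in an ADME assay for permeability, using PAMPA, with a stated time of 30 min, at pH 7.4; on this read-out lower numbers stand for lower permeability and higher numbers for higher permeability. In this assay compound 1 gives "nd" (no result reported). Going by the values given here, the only other value shown belongs to compound 2 `N=c1c2c(-c3ccccc3)c(-c3ccccc3)n(CC3CC3)c2ncn1C1CCOCC1`. In this assay compound 2 gives > 1000 10^-6 cm/s, and this is a limit of the assay rather than a number, (the limit of > 1000 10^-6 cm/s in this assay, at which 1 of the 2 values shown sits). Among the compounds with values here, compound 1 and compound 2 share the same core but differ in more than one place, so no step between them is counted here; what the two values show is simply that one is a limit and the other is absent.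

Compound 3 `COc1ccc(Cn2c(-c3ccccc3)c(-c3ccccc3)c3c(=N)n(CCO)cnc32)cc1` is not yet measured. It is related to compound 1 by one change: 2-hydroxyethyl in place of oxan-4-yl on an aromatic nitrogen. Within the data shown here, no measured step tells what this exchange does in this assay, so the size and direction of the step from compound 1 to compound 3 are open; it may be none beyond the scatter, or it may be a real move in either direction.

On that basis compound 3 is expected to give 400 10^-6 cm/s in this assay, with a range from 80 10^-6 cm/s to 1500 10^-6 cm/s, and a fair chance that only a limit is reported.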

Compound 3, apparent permeability: > 1000 10^-6 cm/s
Compound 3 gave a limit, no number; the forecaster's own chance of this, stated with the estimate: 35%; middle value at least 2.5-fold (0.39 log units) from the limit.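

In this assay compound 3 gives > 1000 10^-6 cm/s, which is a limit of the assay and not a number. Going by these compounds alone, compound 1 gives "nd" (no result reported), so no step from compound 1 to compound 3 can be read. The compounds shown leave open the size and direction of the exchange of oxan-4-yl for 2-hydroxyethyl, with the only values shown standing at one limit: the limit of > 1000 10^-6 cm/s in this assay, at which 2 of the 3 values shown sit.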